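The compounds below may be only part of what the source reports. "The series", "measured", "known", "first", "only" and "open" are said of these compounds alone.

Working notes on the series, read in a physicochemical assay for lipophilicity; a higher number here means a more lipophilic compound, a lower number a more polar compound. Compound 1 `CS(=O)(=O)c1ccc(-c2c(Cl)nc(Cl)n2-c2ccc(F)cc2F)cc1` gives 3.64 and compound 2 `CS(=O)(=O)c1ccc(-c2c(Br)ncn2-c2ccc(F)c(F)c2)cc1` gives 3.72. Among the compounds with values here, these two numbers lie within the scatter of each other, so compound 1 stands level with the only other measured compound. Within the data shown here, the two differ in more than one place, so no clean single-change step is available yet.

Compound 3 `CS(=O)(=O)c1ccc(-c2c(Cl)nc(Cl)n2-c2ccc(F)c(F)c2)cc1` is the next to be read. It keeps the core of compound 1 and alters only the group on the aromatic nitrogen, where 3,4-difluorophenyl stands in place of 2,4-difluorophenyl: 3,4-difluorophenyl in place of 2,4-difluorophenyl on an aromatic nitrogen. Compound 2 already carries the 3,4-difluorophenyl and gives 3.72, a number that offers no sign of a large shift. In this assay no step beyond the scatter is expected for this change, and no firm direction is expected either. The expected change is a number 0.04 log units higher from compound 1 to compound 3 (within the scatter). Compound 3 is estimated at 3.68, with an expected range of 3.35 to 4.02.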

Compound 3, partition coefficient: 4.44
For compound 3 the middle estimate is 0.76 log units below the measured one; the whole stated range lies below it.
By their numbers in this assay, from the lowest: compounds 1 and 2 (each within the scatter of the next); then compound 3.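

Within the data shown here, compound 1 and compound 3 give the first clean single-change step: in this assay, 3,4-difluorophenyl in place of 2,4-difluorophenyl on an aromatic nitrogen gives a number 0.80 log units higher from compound 1 to compound 3 (beyond the scatter) on the shared core. The leaving and entering groups hold the same atoms and have the same counts of rings, donors and acceptors, so those counts do not separate the two compounds; the step tracks only how the two fluorines are arranged on the phenyl ring. The step shows that, at this position, with the shared core held fixed, such a rearrangement alone can carry the reading beyond the scatter, but no measurement is available that bears on the origin of this step.

From the compounds shown here alone, this is a single pair on a single core, so it remains open whether the same exchange gives a step of like size on a core with other ring substituents, such as the bromo core of compound 2. Going by these compounds, it also remains open how the reading at this position would respond to a plain phenyl, a 4-fluorophenyl or a 2,6-difluorophenyl group on the aromatic nitrogen.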